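A few compounds are considered here, and "the series" means these few. Any claim that something is new, unique, unknown or untested is made for them only; others in the source may bear on it.

Measured so far in a functional assay on CCRF-CEM cells (Homo sapiens); a lower number here means that less compound is tolerated, a higher number that more compound is tolerated:
- compound 1 `Cc1cn([C@@H]2O[C@H](CO[Si](C)(C)C(C)(C)C)[C@@]3(OS(=O)(=O)C=C3NCC(=O)O)[C@H]2O[Si](C)(C)C(C)(C)C)c(=O)n(C)c1=O` gives 65000 nM
- compound 2 `CCOC(=O)CNC(=O)NC1=CS(=O)(=O)O[C@@]12[C@@H](CO[Si](C)(C)C(C)(C)C)O[C@@H](n1cc(C)c(=O)n(C)c1=O)[C@@H]2O[Si](C)(C)C(C)(C)C` gives 5020 nM

Compound 2 holds the lower of these two numbers, and its gap to compound 1 lies beyond the scatter. Compound 3 `Cc1cn([C@@H]2O[C@H](CO[Si](C)(C)C(C)(C)C)[C@@]3(OS(=O)(=O)C=C3NCC(=O)OCc3ccccc3)[C@H]2O[Si](C)(C)C(C)(C)C)c(=O)n(C)c1=O` has not yet been measured. The change from compound 2 is (benzyloxycarbonyl)methyl in place of ((ethoxycarbonyl)methyl)carbamoyl on an amine nitrogen; in words, (benzyloxycarbonyl)methyl in place of ((ethoxycarbonyl)methyl)carbamoyl on an amine nitrogen.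

Going by the values given here, one measured step bears on this change, since it falls on the same amine nitrogen: a 13-fold lower number from compound 1 to compound 2 (1.11 log units; beyond the scatter), a large step beyond the scatter, with ((ethoxycarbonyl)methyl)carbamoyl in place of carboxymethyl. The entering group matches neither side of that step, and a single step sets no trend, so it serves only as a rough guide to size. In this assay a moderate move to a higher number is expected, smaller than that measured step. The estimated move is a 2.4-fold higher number from compound 2 to compound 3 (0.38 log units; beyond the scatter) and remains uncertain. For compound 3 the estimated value is 12000 nM, with an expected range of 3500 nM to 45000 nM.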

Compound 3, half-maximal cytotoxic concentration: 250000 nM
For compound 3 the middle estimate is 21-fold (1.32 log units) below the measured one, outside the stated range (above it).
By their numbers in this assay, from the lowest: compound 2; then compound 1; then compound 3.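

In this assay the group on this amine nitrogen moves the read-out strongly in both directions: a 50-fold higher number from compound 2 to compound 3 (1.70 log units; beyond the scatter) goes with (benzyloxycarbonyl)methyl in place of ((ethoxycarbonyl)methyl)carbamoyl, and compound 2 now lies beyond the scatter from both other compounds and holds the lowest number of the three. Keeping the nitrogen free of the carbamoyl group and changing only the end of the chain, from carboxylic acid to benzyl ester, gives a smaller, modest shift (a 3.8-fold higher number from compound 1 to compound 3 (0.59 log units; beyond the scatter)), so among these three compounds the lowest number goes with the one carbamoyl-bearing compound, with no compound against this so far. No measured evidence is available to explain these differences.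

Compound 2 differs from the others in both the carbamoyl group and its ethyl ester, so the compounds shown do not separate the contribution of each. An ethyl ester on the carboxymethyl chain without the carbamoyl group, or the carbamoyl group ending in a free carboxylic acid or a benzyl ester, would divide the two, and an unsubstituted amine would give a reference point for this nitrogen.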